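This account rests on a few compounds, and the source may have more. Where it says the series, first, only, none or still open, it means among the compounds named here.

Measured compounds:
compound 1 `O=C(/C=C/CN1CC(Oc2ccc(Oc3c(-c4ccc(F)cc4)sc4cc(O)ccc34)cc2)C1)N1CCCC1`: 8450 nM
compound 2 `C/C=C/C(=O)NCCOc1ccc(Oc2c(-c3ccc(F)cc3)sc3cc(O)ccc23)cc1`: 21700 nM
compound 3 `O=C(/C=C/CNCCOc1ccc(Oc2c(-c3ccc(F)cc3)sc3cc(O)ccc23)cc1)N1CCC1`: 7340 nM

In a functional assay on MCF7 cells (Homo sapiens) for antiproliferative activity, read by CCK-8 assay, with a stated time of 48 h (a lower number here means a stronger inhibitor, a higher number a weaker inhibitor), compound 1 gives 8450 nM, the second highest of the three numbers. Its nearest neighbour is compound 3 with 7340 nM, within the scatter; the furthest is compound 2 with 21700 nM, beyond the scatter and higher. Compound 4 `C=C(C)C(=O)N1CC(Oc2ccc(Oc3c(-c4ccc(F)cc4)sc4cc(O)ccc34)cc2)C1` differs from compound 1 in one place: (1-methylethenyl)carbonyl in place of 3-((pyrrolidin-1-yl)carbonyl)prop-2-en-1-yl on an amine nitrogen in a ring. Within the data shown here, the only measured step that bears on this is a 3.0-fold lower number from compound 2 to compound 3 (0.47 log units; beyond the scatter), where a short acyl group was exchanged for a longer chain ending in an amide and the number fell modestly. The change from compound 1 to compound 4 runs the other way, shortening the group on the amine nitrogen in the ring to a small acyl unit, so a modest rise in number is expected, of about the size seen in that step. The expected step is a 2.0-fold higher number from compound 1 to compound 4 (0.30 log units; within the scatter). Compound 4 is therefore estimated to give 17000 nM, with a range of 7000 nM to 45000 nM.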

Compound 4, half-maximal inhibitory concentration: > 25000 nM
Compound 4 was reported as a limit; the forecaster's own chance of this, stated with the estimate: 10%; at least 1.4-fold (0.16 log units) between middle value and limit.
By their numbers in this assay, from the lowest: compounds 3 and 1 (each within the scatter of the next); then compound 2. At a limit, above all of these: compound 4.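

In this assay compound 4 stands only as a limit and not as a number: the limit of > 25000 nM in this assay, at which 1 of the 4 values shown sits. On the amine nitrogen in the four-membered non-aromatic ring, (1-methylethenyl)carbonyl in place of 3-((pyrrolidin-1-yl)carbonyl)prop-2-en-1-yl gives an at least 2.9-fold higher number from compound 1 to compound 4 (0.47 log units; beyond the scatter), which shows at this ring nitrogen the same direction as the earlier open-chain step, a 3.0-fold lower number from compound 2 to compound 3 (0.47 log units; beyond the scatter): the small acyl group goes with the higher number. The other steps are an at least 3.4-fold higher number from compound 3 to compound 4 (0.53 log units; beyond the scatter), beyond the scatter, and an at least 1.1-fold higher number from compound 2 to compound 4 (0.06 log units; that floor lies within the scatter), whose floor leaves those two compounds without a readable order.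

Going by these compounds, it remains open whether the effect follows the length of the chain or its terminal pyrrolidine amide. A chain ending in a dimethylamine, or a plain acetyl group, on the same ring nitrogen would help separate the two.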